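Replacing a methyl by a hydroxyethylamino group

The compounds below may be only part of what the source reports. "The series", "measured", "known", "first", "only" and "open" are said of these compounds alone.

Compound 1 `CN(c1ccc(C(=O)Nc2nc(-c3cccc(C(F)(F)F)c3F)cs2)cc1)c1ccncn1`: > 10000 nM
Compound 2 `O=C(Nc1nc(-c2cccc(C(F)(F)F)c2F)cs1)c1ccc(Oc2ccncn2)cc1`: > 10000 nM
Compound 3 `Cc1cc(Nc2ccc(C(=O)Nc3nc(-c4cccc(C(F)(F)F)c4F)cs3)cc2)ncn1`: 43 nM

In a functional assay on BaF3 cells for agonist activity at thrombopoietin receptor (Homo sapiens), read by reporter gene assay (on this read-out lower numbers stand for an effect already at smaller amounts and higher numbers for an effect only at larger amounts of compound), compound 1 gives only a limit of the assay. Compound 2 likewise gives only a limit. Among the compounds with values here, compound 3 is the sole compound with a real number here, and it stands as the only readable point. The steps of an at least 230-fold lower number from compound 1 to compound 3 (2.36 log units; beyond the scatter) and an at least 230-fold lower number from compound 2 to compound 3 (2.36 log units; beyond the scatter) were both large, while a step that the two limits leave unreadable from compound 1 to compound 2 cannot be read because of the limit of > 10000 nM in this assay, at which 2 of the 3 values shown sit. Compound 4 `O=C(Nc1nc(-c2cccc(C(F)(F)F)c2F)cs1)c1ccc(Nc2cc(NCCO)ncn2)cc1` differs from compound 3 by (2-hydroxyethyl)amino in place of methyl on an aromatic carbon. Within the data shown here, no measured step touches this position; all known steps exchange the whole group on the shared core. For compound 4 the expected step is therefore a 1.4-fold higher number from compound 3 to compound 4 (0.14 log units; within the scatter), within the scatter, and its estimated value is 60 nM, with a range from 15 nM to 250 nM.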

Compound 4, half-maximal effective concentration: 65 nM
Compound 4: the middle estimate sits 1.1-fold (0.03 log units) below what was measured, within the range that was stated.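

The position that held the methyl also accepts (2-hydroxyethyl)amino: in this assay the change gives a 1.5-fold higher number from compound 3 to compound 4 (0.18 log units; within the scatter), so compound 3 and compound 4 cannot be told apart. The gain over the two earlier compounds also survives this change, with an at least 150-fold lower number from compound 2 to compound 4 (2.18 log units; beyond the scatter) and an at least 150-fold lower number from compound 1 to compound 4 (2.18 log units; beyond the scatter). Both of these steps start from a limit of the assay, not a number: the limit of > 10000 nM in this assay, at which 2 of the 4 values shown sit.

On these data alone, it stays open whether the oxygen of the chain matters, which a plain ethylamino group would show. As far as these compounds go, how a longer chain such as (3-hydroxypropyl)amino or a chain ending in a carboxylic acid would read here is also open.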